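Swapping phenyl for thiophen-2-yl on a hydroxyphenyl pyridine core

This account rests on a few compounds, and the source may have more. Where it says the series, first, only, none or still open, it means among the compounds named here.

Measured compounds:
- compound 1, `Oc1ccc(-c2cc(-c3ccccc3)cc(-c3ccccc3)n2)cc1`: 1400 nM
- compound 2, `Oc1ccc(-c2cc(-c3ccccc3)cc(-c3cccs3)n2)cc1`: 1700 nM
- compound 3, `Oc1cccc(-c2cc(-c3ccccc3)nc(-c3ccccc3)c2)c1`: 13500 nM

In a functional assay on HL-60 cells (Homo sapiens) for cytotoxicity, read by ELISA, with a stated time of 2 days (a higher number here means a weaker inhibitor, a lower number a stronger inhibitor), compound 1 gives 1400 nM, and compound 2 gives 1700 nM. The change between them, (thiophen-2-yl in place of phenyl on an aromatic carbon), produced a 1.2-fold higher number from compound 1 to compound 2 (0.08 log units; within the scatter). Compound 3 gives 13500 nM in this assay; it has the same atoms as compound 1 joined differently, and the difference between the two cores is not broken down here. The same kind of change made from compound 1 to compound 2 is now made from compound 3 to the unmeasured compound 4, `Oc1cccc(-c2cc(-c3ccccc3)nc(-c3cccs3)c2)c1`: thiophen-2-yl in place of phenyl on an aromatic carbon. The place differs in one respect: in compound 3 the carbon is meta to a 3-hydroxyphenyl group, where in compound 1 it was meta to a 4-hydroxyphenyl group, so the change is the same kind of change and not the same. Because the earlier swap gave a 1.2-fold higher number from compound 1 to compound 2 (0.08 log units; within the scatter), the step from compound 3 to compound 4 is expected to be small, a 1.2-fold higher number from compound 3 to compound 4 (0.07 log units; within the scatter). Compound 4 is therefore estimated at 16000 nM, between 7000 nM and 36000 nM.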

Compound 4, half-maximal inhibitory concentration: 18900 nM
For compound 4 the middle estimate is 1.2-fold (0.07 log units) below the measured one; the measured number falls inside the stated range.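

In this assay, putting thiophen-2-yl in place of phenyl on the core of compound 3 gave a 1.4-fold higher number from compound 3 to compound 4 (0.15 log units; within the scatter), a step too small to read as a real change. Set beside the same swap on the core of compound 1, this step does not stand apart: the same change on two cores in this assay, a 1.2-fold higher number (0.08 log units; within the scatter) from compound 1 to compound 2 and a 1.4-fold higher number (0.15 log units; within the scatter) from compound 3 to compound 4, 1.2-fold (0.06 log units) apart, within the scatter of two such steps. This shows that on these two cores the swap carried over as a step within the scatter, but two pairs cannot show that it would do so on other cores, and steps this small cannot show that the two rings are truly equal in this assay.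

The compounds shown leave open how a different kind of group would fare in place of the phenyl next to the ring nitrogen, such as an amine, a carboxylic acid or a furan-2-yl ring. They also leave open whether the swap would stay this small on a core carrying a methoxy group in place of the hydroxyl.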